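Benzyl to methylsulfonyl on the oxygen: working notes

The source may report more compounds than this note shows. Statements on the series, on what has been measured and on what is new or still open speak of the compounds shown alone.

Measured so far in a functional assay on P388 cells (Mus musculus) for cytotoxicity (on this read-out lower numbers stand for an effect already at smaller amounts and higher numbers for an effect only at larger amounts of compound), where a value with a sign is a limit of the assay and not a number:
- compound 1 `c1ccc(COc2cc(-c3ccccc3)nc3ccccc23)cc1`: > 10 ug/mL
- compound 2 `Oc1ccc2nc(-c3ccccc3)cc(O)c2c1`: 2.86 ug/mL
- compound 3 `Oc1cc(-c2ccccc2)nc2c(O)cccc12`: > 10 ug/mL

Compound 1 gives > 10 ug/mL in this assay, and this is a limit, not a number. Compound 1 and compound 3 share the same reading, (the limit of > 10 ug/mL in this assay, at which 2 of the 3 values shown sit). Only compound 2 has a true number, 2.86 ug/mL, and it carries two hydroxyl groups where compound 1 carries a single benzyloxy group.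

The next compound to be measured is compound 4 `CS(=O)(=O)Oc1cc(-c2ccccc2)nc2ccccc12`. It has methylsulfonyl in place of benzyl on an oxygen on an aromatic ring. The same change, read one bond further out, is benzyloxy to (methylsulfonyl)oxy.

Going by the values given here, no measured pair isolates this kind of change, and compound 1 offers no number to start from. No step beyond the usual scatter can therefore be expected with any confidence in this assay, and any movement would more likely be toward lower numbers. The expected change is an at least 1.1-fold lower number from compound 1 to compound 4 (0.04 log units; that floor lies within the scatter). A reading that is again only a limit is somewhat more likely than a number. For compound 4 the estimated value is 9 ug/mL, with an expected range from 3 ug/mL to 30 ug/mL.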

Compound 4, half-maximal effective concentration: > 10 ug/mL
Compound 4 gave a limit, no number; the forecaster's own chance of this, stated with the estimate: 60%; middle value at least 1.1-fold (0.04 log units) away from the limit.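

In this assay compound 4 gives > 10 ug/mL, a limit and not a number. Compound 1 is also a limit, so no step can be read between compound 1 and compound 4: the limit of > 10 ug/mL in this assay, at which 3 of the 4 values shown sit.

The compounds shown leave open whether methylsulfonyl in place of benzyl on an oxygen on an aromatic ring changes the read-out at all.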